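The compounds below may be only part of what the source reports. "The series", "measured", "known", "first", "only" and "open" are said of these compounds alone.

Compound 1 `CCCCCCCCCCCCN(C)C(=O)Cn1cc(Cc2cnc(=O)n(C)c2)c(=O)nc1SCc1ccc(F)cc1`, compound 2 `CCCCCCCCCCCCN(C)C(=O)Cn1cc(Cc2cnc(=O)n(CCO)c2)c(=O)nc1SCc1ccc(F)cc1` and compound 3 `CCCCCCCCCCCCN(C)C(=O)Cn1cc(Cc2cnc(=O)n(CC(=O)NC)c2)c(=O)nc1SCc1ccc(F)cc1` share one core and differ only in the group carried on the saturated chain carbon bound to the aromatic nitrogen. In a functional assay on a cell-free system (plasma, Oryctolagus cuniculus) for inhibition of platelet-activating factor acetylhydrolase (Homo sapiens), tested at 100 nM (a higher number here means more inhibition at the concentration tested (going by the name of the read-out), a lower number less inhibition), compound 1 gives 32%, compound 2 gives 36% and compound 3 gives 28%. Compound 3 stands lowest of the three numbers, but its steps to both neighbours, a number 4 percentage points lower from compound 1 to compound 3 (within the scatter) and a number 8 percentage points lower from compound 2 to compound 3 (within the scatter), are within the scatter, so the three compounds cannot be ordered.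

Compound 4 `CCCCCCCCCCCCN(C)C(=O)Cn1cc(Cc2cnc(=O)n(CC(=O)NCCO)c2)c(=O)nc1SCc1ccc(F)cc1` differs from compound 3 by hydroxymethyl in place of hydrogen on a saturated chain carbon bound to an amide-type nitrogen. The closest measured precedent is a number 4 percentage points higher from compound 1 to compound 2 (within the scatter), where the same hydroxymethyl for hydrogen exchange, on a saturated chain carbon bound to an aromatic nitrogen, stayed within the scatter. Among the measured compounds shown here, no measured step here exceeds the scatter, and no step at the amide-type nitrogen has been measured. Compound 4 is therefore expected to show no step beyond the scatter in this assay, namely a number 2 percentage points higher from compound 3 to compound 4 (within the scatter). Compound 4 is estimated at 30%, with a range from 19% to 42%.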

Compound 4, a percentage reported as inhibition, at one concentration (the size of the read-out at that concentration, not a potency): 37%
Compound 4: middle estimate off by 7 percentage points, on the low side; the range from low to high includes it.
By their numbers in this assay, from the lowest: compounds 3, 1, 2 and 4 (each within the scatter of the next).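

In this assay, hydroxymethyl in place of hydrogen also stays within the scatter on a saturated chain carbon bound to an amide-type nitrogen, giving a number 9 percentage points higher from compound 3 to compound 4 (within the scatter). On the saturated chain carbon bound to an aromatic nitrogen, (2-hydroxyethyl)carbamoyl in place of hydroxymethyl gives a number 1 percentage points higher from compound 2 to compound 4 (within the scatter), and in place of hydrogen it gives a number 5 percentage points higher from compound 1 to compound 4 (within the scatter), so all four compounds remain unordered and none of these groups at this position has so far given a step beyond the scatter. The hydroxymethyl exchange reads alike at the two places: the same change on two cores in this assay, a number 4 percentage points higher (within the scatter) from compound 1 to compound 2 and a number 9 percentage points higher (within the scatter) from compound 3 to compound 4, 5 percentage points apart, within the scatter of two such steps.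

Going by these compounds, whether an amine, a carboxylic acid or a longer chain at this position would give a step beyond the scatter stays open. Each number also comes from one concentration, so none of them gives a potency for any of the four compounds.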